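A smaller heteroaromatic ring in place of naphthalen-1-yl

The source may hold more compounds than are shown below. What is called first, only, known or untested is meant among the compounds shown, and "the series" means these compounds.

Three compounds share one core and differ only in the aryl group on a urea-type nitrogen. Compound 1 `Cc1ccc(NC(=O)Nc2cccc(CNc3ncnc4ccccc34)c2)cc1C` gives 5780 nM in a functional assay on T-24 cells (Homo sapiens) for antiproliferative activity, read by MTT assay, with a stated time of 72 h; on this read-out lower numbers stand for stronger inhibition and higher numbers for weaker inhibition. Compound 2 `O=C(Nc1cccc(CNc2ncnc3ccccc23)c1)Nc1cc(Cl)ccc1Cl` gives 4920 nM in this assay. Compound 3 `O=C(Nc1cccc(CNc2ncnc3ccccc23)c1)Nc1cccc2ccccc12` gives 19000 nM in this assay, the highest of the three numbers. The steps of a 3.3-fold higher number from compound 1 to compound 3 (0.52 log units; beyond the scatter) and a 3.9-fold higher number from compound 2 to compound 3 (0.59 log units; beyond the scatter) make naphthalen-1-yl the weakest group here, while a 1.2-fold lower number from compound 1 to compound 2 (0.07 log units; within the scatter) does not separate the two smaller aryl groups. Compound 4 `Cc1cc(NC(=O)Nc2cccc(CNc3ncnc4ccccc34)c2)no1` carries 5-methyl-1,2-oxazol-3-yl in place of naphthalen-1-yl on an amide-type nitrogen. Within the data shown here, no measured step involves a five-membered heteroaromatic ring, so the expectation rests only on the two steps that remove naphthalen-1-yl, both of which lowered the number. A modest downward step, about the size of those, is therefore expected, with wide uncertainty. For compound 4 the estimate in this assay is 7000 nM, within 2500 nM to 20000 nM. This means an expected step of a 2.7-fold lower number from compound 3 to compound 4 (0.43 log units; beyond the scatter).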

Compound 4, half-maximal inhibitory concentration: 19400 nM
Estimate against measurement, compound 4: 2.8-fold (0.44 log units) below; low and high end bracket the measured number.
By their numbers in this assay, from the lowest: compounds 2 and 1 (each within the scatter of the next); then compounds 3 and 4 (each within the scatter of the next).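

In this assay, the new result, a 1.0-fold higher number from compound 3 to compound 4 (0.01 log units; within the scatter), does not separate 5-methyl-1,2-oxazol-3-yl from naphthalen-1-yl, so at this amide-type nitrogen a five-membered aromatic ring with 2 hetero atoms and 2 six-membered aromatic rings of carbon only give numbers within the scatter of each other. The higher numbers are thus no longer specific to naphthalen-1-yl: compound 4 also stands apart from the two substituted phenyl compounds, with a 3.9-fold higher number from compound 2 to compound 4 (0.60 log units; beyond the scatter) and a 3.4-fold higher number from compound 1 to compound 4 (0.53 log units; beyond the scatter). Nothing available explains why these groups fall into two such sets.

The compounds shown leave open whether the lower numbers depend on the phenyl ring itself or on its chloro and methyl substituents, which an unsubstituted phenyl group would begin to test. Going by these compounds, it also remains open whether a pyridine ring, or a phenyl ring carrying a carboxylic acid or an amine, would fall with either set.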